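Removing a Pyrazole Methyl in a Benzyloxy Carbamate Series

The source may hold more compounds than are shown below. What is called first, only, known or untested is meant among the compounds shown, and "the series" means these compounds.

Measured so far:
compound 1 `O=C(N1CCCN(Cc2ccc(OCc3ccccc3)cc2)CC1)n1cccn1` — 960 nM
compound 2 `Cc1cnn(C(=O)N(C)CCN(C)C(c2ccc(OCc3ccccc3)cc2)c2ccc(OCc3ccccc3)cc2)c1` — > 1000000 nM

In an assay on membranes from brain for binding affinity to Monoacylglycerol lipase ABHD6 (Mus musculus), read by fluorescence, with stated times of 1 h and 30 min (on this read-out lower numbers stand for stronger inhibition and higher numbers for weaker inhibition), compound 1 gives 960 nM. Compound 2 `Cc1cnn(C(=O)N(C)CCN(C)C(c2ccc(OCc3ccccc3)cc2)c2ccc(OCc3ccccc3)cc2)c1` is recorded only as a limit of this assay, > 1000000 nM, so its true value is not known beyond that limit (the limit of > 1000000 nM in this assay, at which 1 of the 2 values shown sits). Compound 3 `CN(CCN(C)C(c1ccc(OCc2ccccc2)cc1)c1ccc(OCc2ccccc2)cc1)C(=O)n1cccn1` differs from compound 2 in one place: hydrogen in place of methyl on an aromatic carbon. Among the measured compounds shown here, no measured pair in this set reports the effect of such a change, so the size and direction of the step must be guessed from the single limit; a change this small is expected to stay within the usual scatter or move only modestly. The step from compound 2 to compound 3 is therefore expected to be an at least 3.3-fold lower number from compound 2 to compound 3 (0.52 log units; beyond the scatter). Compound 3 is estimated at 300000 nM, within 20000 nM to 5000000 nM, most likely again reported only as a limit.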

Compound 3, half-maximal inhibitory concentration: > 1000000 nM
Compound 3 was reported as a limit (the forecaster's own chance of this, stated with the estimate: 70%); middle value at least 3.3-fold (0.52 log units) away from the limit.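

Compound 2 and compound 3 are both recorded only as limits, so no step between them can be read: the limit of > 1000000 nM in this assay, at which 2 of the 3 values shown sit.

The compounds shown leave open how 4-methyl-1H-pyrazol-1-yl and 1H-pyrazol-1-yl compare, and how far compound 2 or compound 3 lies past that limit.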